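Triazole series on a trimethoxyphenyl core: a fluoro-to-methylsulfanyl swap

The source may report more compounds than this note shows. Statements on the series, on what has been measured and on what is new or still open speak of the compounds shown alone.

Measured so far:
- compound 1, `COc1cc(-n2ncnc2-c2cccc(F)c2)cc(OC)c1OC`; in a functional assay on HeLa cells (Homo sapiens) for antiproliferative activity, read by MTT assay, with a stated time of 72 h (a lower number here means a stronger inhibitor, a higher number a weaker inhibitor), compound 1 gives > 10000 nM, a limit of the assay rather than a number.
- compound 2, `CCOc1cccc(-c2ncnn2-c2cc(OC)c(OC)c(OC)c2)c1`; in this assay compound 2 gives > 10000 nM, again only a limit.

Among the compounds with values here, compound 1 therefore stands at the limit, with no number of its own; the one other value shown is a limit too, as the evidence the limit of > 10000 nM in this assay, at which 2 of the 2 values shown sit, records. Within the data shown here, the only measured step, a step that the two limits leave unreadable from compound 1 to compound 2, is unreadable for the same reason.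

Compound 3, `COc1cc(-n2ncnc2-c2ccc(SC)cc2)cc(OC)c1OC`, differs from compound 1 by 4-(methylsulfanyl)phenyl in place of 3-fluorophenyl on an aromatic carbon. Among the measured compounds shown here, no measured step resembles this change, and the single step available gives no readable size. The step from compound 1 to compound 3 is thus expected to be a number no higher from compound 1 to compound 3 (the limit leaves the size open), with no direction supported by the data. Compound 3 is estimated at 10000 nM in this assay, within a range from 2000 nM to 30000 nM, most likely reported only as a limit.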

Compound 3, half-maximal inhibitory concentration: 150 nM
Compound 3: the middle estimate sits 67-fold (1.82 log units) above what was measured; the whole stated range lies above it.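

The change from 3-fluorophenyl to 4-(methylsulfanyl)phenyl, on the aromatic carbon between two ring nitrogen atoms, gives in this assay an at least 66-fold lower number from compound 1 to compound 3 (1.82 log units; beyond the scatter). Within the data shown here, this is the first readable size at this position, and it shows that the aryl group on this carbon can take the series off the limit, which the ethoxy of compound 2 did not show. Compound 3 alone has a number of its own, and the step from compound 1 to compound 2 still cannot be read: the limit of > 10000 nM in this assay, at which 2 of the 3 values shown sit.

The change replaces the substituent and also alters its numbered place on the phenyl ring, so the compounds shown leave open which of the two carries the step. Also open, on these data alone, is whether an amine or a longer sulfur-bearing chain in place of methylsulfanyl would hold this activity.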